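Swapping the Amine on Compound 1: An Expectation

This account rests on a few compounds, and the source may have more. Where it says the series, first, only, none or still open, it means among the compounds named here.

Compound 1 `CCCCCCCCCCCCCCCCc1c(C)c(N(C)C)nc(C)c1O` is a pyridinol carrying a long hexadecyl chain and a dimethylamino group. Going by the values given here, in a functional assay on cells (Lymphocyte, Homo sapiens), read by trypan blue exclusion, with a stated time of 16 h, tested at 0.5 uM (on this read-out lower numbers stand for a weaker effect and higher numbers for a stronger effect at the one concentration tested), compound 1 gives 56%, the lower of the two numbers measured so far. Among the compounds with values here, compound 2 `CCCCCCCCCCc1c(C)c(N(C)C)nc(C)c1O` differs from compound 1 only in the length of the chain, and in this assay compound 2 gives 87%; the step of a number 31 percentage points higher from compound 1 to compound 2 (beyond the scatter) is the only measured step here.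

Compound 3 `CCCCCCCCCCCCCCCCc1c(C)c(N2CCC2)nc(C)c1O` keeps the hexadecyl chain of compound 1 and changes only the amine: azetidin-1-yl in place of dimethylamino on an aromatic carbon. Within the data shown here, no measured step touches that position; the one step known concerns the chain alone. With nothing to point either way, compound 3 is expected to show no step beyond the scatter, that is no change at the digits printed from compound 1 to compound 3 (within the scatter). The estimate for compound 3 in this assay is therefore 56%, within a range from 35% to 78%.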

Compound 3, a percentage reported as activity, at one concentration (the size of the read-out at that concentration, not a potency): 95%
Beside the measured number, compound 3's estimate is 39 percentage points below it; measured number above the stated range.
By their numbers in this assay, from the lowest: compound 1; then compounds 2 and 3 (each within the scatter of the next).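

The position para to the hydroxy group turns out to matter: with the hexadecyl chain held constant, azetidin-1-yl in place of dimethylamino gives, in this assay, a number 39 percentage points higher from compound 1 to compound 3 (beyond the scatter). Until now, only a change in the chain had been seen to shift this read-out, so the amine is a second place on the molecule where a single change has a large effect. Nothing available explains why this small ring outperforms the open dimethylamino group.

From the compounds shown here alone, it remains open whether azetidin-1-yl would have a similar effect on the shorter chain of compound 2. It is also unclear how a larger ring amine such as pyrrolidin-1-yl or piperidin-1-yl, or an open-chain amine such as diethylamino, would behave at this position.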